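This account rests on a few compounds, and the source may have more. Where it says the series, first, only, none or still open, it means among the compounds named here.

Measured so far in a functional assay on MCF7 cells (Homo sapiens) for inhibition, read by sulforhodamine B assay; a lower number here means a stronger inhibitor, a higher number a weaker inhibitor:
- Compound 1 `Cc1ccc(NC2=CC(=O)c3c(nc4n3[C@H]3OC[C@@H](O)[C@H]3OC4)C2=O)cc1C`: 4950 nM
- Compound 2 `O=C1C(N2CCCC2)=CC(=O)c2c1nc1n2[C@H]2OC[C@@H](O)[C@H]2OC1`: > 16000 nM, a limit of the assay
- Compound 3 `CCCc1ccc(NC2=CC(=O)c3c(nc4n3[C@H]3OC[C@@H](O)[C@H]3OC4)C2=O)cc1`: > 4000 nM, a limit of the assay

Compound 3 stands at > 4000 nM, which is a limit of the assay and not a number. Its true position on the scale is therefore unknown.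

Compound 4 `O=C1C(Nc2cccc(Cl)c2)=CC(=O)c2c1nc1n2[C@H]2OC[C@@H](O)[C@H]2OC1` has not yet been measured. It keeps the shared core and changes only the group on the amine nitrogen: 3-chlorophenyl in place of 4-propylphenyl, (3-chlorophenyl in place of 4-propylphenyl on an amine nitrogen).

Within the data shown here, two measured steps bear on this change. The closest swaps one aromatic group on that same nitrogen for another, but it gives a step that the limit leaves unreadable from compound 1 to compound 3, so it sets no size. The other removes the aromatic amine altogether and gives an at least 3.2-fold higher number from compound 1 to compound 2 (0.50 log units; beyond the scatter), which is beyond the scatter. Among the measured compounds shown here, compound 4 keeps an aromatic ring on the amine nitrogen, so the most useful anchor is compound 1 at 4950 nM, the only exact value available.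

No step beyond the scatter is expected, and the estimated step is a step that the limit leaves unreadable from compound 3 to compound 4. For compound 4 the expected value is 5000 nM, with an estimated range of 1800 nM to 16000 nM.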

Compound 4, half-maximal inhibitory concentration: 2970 nM
The estimate for compound 4 lay 1.7-fold (0.23 log units) above the measured number, within the range that was stated.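

In this assay, compound 4 gives a second exact number for an aromatic ring on this amine nitrogen, and swapping 3,4-dimethylphenyl for 3-chlorophenyl gives a 1.7-fold lower number from compound 1 to compound 4 (0.22 log units; within the scatter), so these two rings cannot be told apart here. Replacing pyrrolidin-1-yl with (3-chlorophenyl)amino on the double-bonded ring carbon gives an at least 5.3-fold lower number from compound 2 to compound 4 (0.73 log units; beyond the scatter), and that floor rests on a limit of the assay for compound 2; compounds 1 and 4 now both point to an aromatic amine being better than pyrrolidin-1-yl at this carbon, while compound 3 can neither confirm nor contradict that. Swapping 4-propylphenyl for 3-chlorophenyl gives an at least 1.3-fold lower number from compound 3 to compound 4 (0.12 log units; that floor lies within the scatter), and since the value of compound 3 is a limit of the assay, this step cannot show whether the two groups truly differ.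

Going by these compounds, the true value of compound 3 stays unknown, so the effect of the propyl chain on the ring remains unsettled. The compounds shown also leave open how a benzylamine, with a carbon link between the nitrogen and the ring, or a phenyl ring carrying a carboxylic acid would behave at this nitrogen.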